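Working notes: from compound 1 to compound 3

A few compounds are considered here, and "the series" means these few. Any claim that something is new, unique, unknown or untested is made for them only; others in the source may bear on it.

Compound 1 `COc1ccc(/C=C2\CN(Cc3cn(Cc4cccc(Cl)c4)nn3)C/C(=C\c3ccc(OC)cc3)C2=O)cc1`: 99000 nM
Compound 2 `Cc1ccc(/C=C2\CN(C(=S)SCc3cn(Cc4ccccc4F)nn3)C/C(=C\c3ccc(C)cc3)C2=O)cc1`: > 100000 nM

All readings come from a functional assay on MCF7 cells (Homo sapiens) for cytotoxicity, read by MTT assay, with a stated time of 24 h; a higher number here means a weaker inhibitor, a lower number a stronger inhibitor. For the measured compounds named here, compound 1 gives 99000 nM, the only true number so far, and it stands at the weak end of what can be read. Compound 2 reads > 100000 nM, which is a limit of the assay and not a number.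

The next compound to be measured is compound 3 `COc1ccc(/C=C2\CN(Cc3cn(Cc4ccc(F)cc4)nn3)C/C(=C\c3ccc(OC)cc3)C2=O)cc1`. It keeps the core of compound 1 and differs in one group: 4-fluorophenyl in place of 3-chlorophenyl on a saturated chain carbon bound to an aromatic nitrogen. In words, 4-fluorophenyl stands in place of 3-chlorophenyl on a saturated chain carbon bound to an aromatic nitrogen. Going by the values given here, no measured pair isolates this change, so no step beyond the scatter is expected in this assay, and no direction is favoured. The expectation rests on compound 1 at 99000 nM. The estimated step is a 1.2-fold lower number from compound 1 to compound 3 (0.09 log units; within the scatter). For compound 3 the expected value is 80000 nM, with an estimated range of 35000 nM to 130000 nM.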

Compound 3, half-maximal inhibitory concentration: > 100000 nM
Compound 3: a limit, no number (the forecaster's own chance of this, stated with the estimate: 35%); middle value at least 1.2-fold (0.09 log units) away from the limit.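

In this assay, 4-fluorophenyl in place of 3-chlorophenyl on a saturated chain carbon bound to an aromatic nitrogen gives a number no lower from compound 1 to compound 3 (the limit leaves the size open). Compound 3 reads > 100000 nM, which is a limit of the assay and not a number, so the size of this step cannot be read. This change therefore brings no gain in strength at this position, and the only true number in the series remains at the edge of the readable range: the limit of > 100000 nM in this assay, at which 2 of the 3 values shown sit.

The change alters both the halogen and its place on the ring, and the compounds shown do not separate the two; 4-chlorophenyl or 3-fluorophenyl would do so. Also open, going by these compounds, is whether an amine or a carboxylic acid at this position would give a readable number in this assay.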